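The compounds below may be only part of what the source reports. "The series", "measured", "known", "first", "only" and "open" are said of these compounds alone.

Compound 1 `C#C[C@@H]1[C@@H](O)[C@H](n2ccc(=O)[nH]c2=O)O[C@@H]1CO`: > 350000 nM
Compound 2 `C#CC[C@]1(O)[C@@H](CO)O[C@@H](n2ccc(=O)[nH]c2=O)[C@@H]1O`: > 350000 nM
Compound 3 `C=C[C@@]1(O)[C@@H](CO)O[C@@H](n2ccc(N)nc2=O)[C@@H]1O`: 60800 nM

All three values come from a functional assay on L1210 cells (Mus musculus), read by MTT assay; on this read-out lower numbers stand for stronger inhibition and higher numbers for weaker inhibition. Compound 1 gives > 350000 nM, which is a limit of the assay and not a number. Compound 2 gives > 350000 nM, likewise a limit of the assay. Among the measured compounds shown here, compound 3 gives 60800 nM, the only numerical value in the set. For the measured compounds named here, compound 2 therefore stands at the limit, where two of the three values sit (the limit of > 350000 nM in this assay, at which 2 of the 3 values shown sit); how far beyond it compound 2 actually lies is not known, and no step between measured compounds is available to calibrate the series.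

Compound 4 `C#CC[C@@]1(O)[C@@H](CO)O[C@@H](n2ccc(=O)[nH]c2=O)[C@@H]1O` has not been measured in this assay. Relative to compound 2 the change is the two compounds have the same atoms and bonds and differ only in configuration as drawn: 1 of 4 stereo elements differ; a stereocentre at a saturated ring carbon is drawn R in compound 2 and S in compound 4. The two compounds share every atom and bond and differ only in configuration at one saturated ring carbon. Going by the values given here, with compound 2 at the limit and no measured step to draw on, the expectation for compound 4 is that it stays where compound 2 stands: the expected step of a number no higher from compound 2 to compound 4 (the limit leaves the size open) is none beyond the scatter, most probably with the assay again reporting only a limit. Compound 4 is expected at 350000 nM, in the range 60000 nM to 1500000 nM.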

Compound 4, half-maximal inhibitory concentration: > 350000 nM
Compound 4: only a limit was reported; the forecaster's own chance of this, stated with the estimate: 70%; the middle value lies on the limit itself.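

In this assay compound 2 and compound 4 each give only a limit of the assay, so no step can be read between these two compounds, which differ only in configuration at one saturated ring carbon. The compounds shown leave open whether that configuration changes inhibition at all: the limit of > 350000 nM in this assay, at which 3 of the 4 values shown sit.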